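The source may report more compounds than this note shows. Statements on the series, on what has been measured and on what is new or still open speak of the compounds shown alone.

In a functional assay on NCI-H460 cells (Homo sapiens) for antiproliferative activity, with a stated time of 72 h (on this read-out lower numbers stand for stronger inhibition and higher numbers for weaker inhibition), compound 1 (`Nc1ncnn2c([C@@H]3O[C@H](CO)[C@@H](O)[C@H]3O)cc(C#CC3CC3)c12`), which ends in a cyclopropyl group on its triple bond, gives 80 nM. Compound 2 (`Nc1ncnn2c([C@@H]3O[C@H](CO)[C@@H](O)[C@H]3O)cc(C#Cc3ccc(F)cc3)c12`) gives 79400 nM, the higher of the two numbers and therefore the weaker inhibition. Compound 3 (`Nc1ncnn2c([C@@H]3O[C@H](CO)[C@@H](O)[C@H]3O)cc(C#Cc3cccs3)c12`) keeps the shared core and the triple bond, and only the end group changes: thiophen-2-yl in place of 4-fluorophenyl on a triple-bonded carbon. Just one measured step bears on this change, and only indirectly. Replacing cyclopropyl with 4-fluorophenyl gave a 990-fold higher number from compound 1 to compound 2 (3.00 log units; beyond the scatter), so placing an aromatic ring at this spot coincided with a very large loss. Thiophen-2-yl is also an aromatic ring, which suggests that compound 3 will resemble compound 2 more than compound 1. However, compound 2 is the only measured example with an aromatic ring here, so the size of any shift is poorly defined. A moderate recovery seems the likeliest outcome, with the expected change being a 7.9-fold lower number from compound 2 to compound 3 (0.90 log units; beyond the scatter). For compound 3 the estimated value is 10000 nM, with an expected range from 800 nM to 80000 nM.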

Compound 3, half-maximal inhibitory concentration: 26600 nM
The estimate for compound 3 lay 2.7-fold (0.42 log units) below the measured number; low and high end bracket the measured number.
By their numbers in this assay, from the lowest: compound 1; then compound 3; then compound 2.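

In this assay, a second aromatic end group on the triple bond also stays far from the cyclopropyl compound, with a 330-fold higher number from compound 1 to compound 3 (2.52 log units; beyond the scatter). The large loss first seen with 4-fluorophenyl is therefore not confined to that single ring: both aromatic end groups shown here give much higher numbers than cyclopropyl does. Exchanging one aromatic ring for the other has a real but much smaller effect, with a 3.0-fold lower number from compound 2 to compound 3 (0.47 log units; beyond the scatter), so thiophen-2-yl regains only a small part of the ground lost and the choice of aromatic ring is a secondary matter at this position. No measurement available here explains these differences.

With a single non-aromatic end group to compare, it remains unclear whether the high potency of compound 1 depends on the cyclopropyl ring itself or would extend to other non-aromatic groups, such as a cyclohexyl ring, a short methyl group or a longer butyl chain. From the compounds shown here alone, it is also open how a plain phenyl ring without fluorine, or a ring carrying an amine, would fall relative to compound 2 and compound 3.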